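The compounds below may be only part of what the source reports. "The series", "measured", "known", "first", "only" and "open" are said of these compounds alone.

Going by the values given here, compound 1 `COC(=O)c1cccc2c1nc(-c1c(F)cccc1F)n2Cc1c(F)cccc1F` was examined in a toxicity assay on CCRF-CEM cells (Homo sapiens) for cytotoxicity (a lower number here means that less compound is tolerated, a higher number that more compound is tolerated), where compound 1 gives 57.7 uM, the highest of the three numbers measured so far, although its nearest neighbour sits within the scatter. Compound 2 `CC(=O)Nc1cccc2c1nc(-c1c(F)cccc1F)n2Cc1c(F)cccc1F` carries acetamido in place of methoxycarbonyl on an aromatic carbon, and in this assay compound 2 gives 39.3 uM. Compound 3 `CNc1cccc2c1nc(-c1c(F)cccc1F)n2Cc1c(F)cccc1F` carries methylamino in place of methoxycarbonyl on an aromatic carbon, and in this assay compound 3 gives 27.2 uM. The three steps between them are a 1.5-fold lower number from compound 1 to compound 2 (0.17 log units; within the scatter), a 2.1-fold lower number from compound 1 to compound 3 (0.33 log units; beyond the scatter) and a 1.4-fold lower number from compound 2 to compound 3 (0.16 log units; within the scatter).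

Compound 4 `CC(C)=CCc1cccc2c1nc(-c1c(F)cccc1F)n2Cc1c(F)cccc1F` has not yet been measured. It differs from compound 1 in one place: 3-methylbut-2-en-1-yl in place of methoxycarbonyl on an aromatic carbon. The two measured steps that start from compound 1 both exchange the methoxycarbonyl group and both end at a lower number, one within the scatter and one modestly beyond it. Neither of those steps brings in a group made of carbon only, so the new change is not a copy of either, but both point the same way. A step of similar modest size, downward, is therefore expected for compound 4, namely a 2.3-fold lower number from compound 1 to compound 4 (0.36 log units; beyond the scatter). Compound 4 is estimated to give 25 uM, with a range from 10 uM to 60 uM.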

Compound 4, half-maximal toxic concentration: 28.3 uM
Beside the measured number, compound 4's estimate is 1.1-fold (0.05 log units) below it; the range from low to high includes it.
By their numbers in this assay, from the lowest: compounds 3, 4, 2 and 1 (each within the scatter of the next, the first and the last beyond it).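

Going by these compounds alone, every group that replaced methoxycarbonyl on this aromatic carbon in the earlier compounds held a nitrogen, whereas 3-methylbut-2-en-1-yl is made of carbon only and has no hydrogen-bond acceptors. Even so, this assay shows a 2.0-fold lower number from compound 1 to compound 4 (0.31 log units; beyond the scatter) and this modest step lies beyond the scatter, as the step to the methylamino compound does, so a nitrogen in the entering group is not needed for a step of this kind. The new group also cannot be told apart from the two nitrogen-bearing groups, as there is a 1.0-fold higher number from compound 3 to compound 4 (0.02 log units; within the scatter) and also a 1.4-fold lower number from compound 2 to compound 4 (0.14 log units; within the scatter) and both steps lie within the scatter. No measurement shown gives a reason for these numbers.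

From the compounds shown here alone, whether a carboxylic acid or an unsubstituted amine on this aromatic carbon would give a number closer to that of compound 1 or to that of compound 4 remains open. Going by these compounds, it is equally open whether a longer carbon chain, or a saturated chain in place of 3-methylbut-2-en-1-yl, would leave the number in the same range.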